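Notes on a hydroxamic acid series: the tert-butyl step

The source may report more compounds than this note shows. Statements on the series, on what has been measured and on what is new or still open speak of the compounds shown alone.

Measured so far:
Compound 1, `O=C(NO)c1ccc(N(Cc2ccc(C(F)(F)F)cc2)C(=O)CN(Cc2ccccc2C(F)(F)F)S(=O)(=O)c2ccc(F)cc2)cc1`, in an assay on Sf9 cells for inhibition of histone deacetylase 11 (Homo sapiens), read by mobility shift assay (a higher number here means a weaker inhibitor, a lower number a stronger inhibitor), compound 1 gives 304 nM.
Compound 2, `CC(C)(C)c1ccc(CN(C(=O)CN(Cc2ccccc2C(F)(F)F)S(=O)(=O)c2ccc(F)c(F)c2)c2ccc(C(=O)NO)cc2)cc1`, compound 2 gives 254 nM.
Compound 3, `O=C(NO)c1ccc(N(Cc2ccc(C(F)(F)F)cc2)C(=O)CN(Cc2ccccc2C(F)(F)F)S(=O)(=O)c2ccc(F)cc2F)cc1`, compound 3 gives 346 nM.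

The three numbers lie close together. Compound 3 sits nearest to compound 1, and the gap between them is within the scatter, as is the gap between compound 3 and compound 2.

The next compound, compound 4, `CC(C)(C)c1ccc(CN(C(=O)CN(Cc2ccccc2C(F)(F)F)S(=O)(=O)c2ccc(F)cc2F)c2ccc(C(=O)NO)cc2)cc1`, is not yet measured. It differs from compound 3 in one place: tert-butyl in place of trifluoromethyl on an aromatic carbon.

Among the compounds with values here, the one step measured so far, a 1.1-fold higher number from compound 1 to compound 3 (0.06 log units; within the scatter), concerns a different position and does not bear on this change. Within the data shown here, compound 2, which carries the tert-butyl group, and compound 3, which carries the trifluoromethyl group, differ in two places at once, so their pair gives no clean step; all that can be said is that their two values fall within the scatter of each other. Nothing in the series therefore points to a step beyond the scatter for this change, in either direction.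

For compound 4 the expected value in this assay is 310 nM, within a range of 150 nM to 650 nM, which means an expected step of a 1.1-fold lower number from compound 3 to compound 4 (0.05 log units; within the scatter).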

Compound 4, half-maximal inhibitory concentration: 288 nM
The estimate for compound 4 lay 1.1-fold (0.03 log units) above the measured number, within the range that was stated.
By their numbers in this assay, from the lowest: compounds 2, 4, 1 and 3 (each within the scatter of the next).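

In this assay, the swap at this position can now be read on its own, free of any second change: tert-butyl in place of trifluoromethyl, para to a large group, gives a 1.2-fold lower number from compound 3 to compound 4 (0.08 log units; within the scatter), so in this pair the move from 4-(trifluoromethyl)benzyl to 4-(tert-butyl)benzyl leaves the number within the scatter. The new compound also splits the two-place difference between compound 2 and compound 3 into single steps, and the second of these, 2,4-difluorophenyl in place of 3,4-difluorophenyl on a sulfonyl sulfur, gives a 1.1-fold higher number from compound 2 to compound 4 (0.05 log units; within the scatter), which is likewise within the scatter. No measurement at hand bears on the reason for either step.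

From the compounds shown here alone, each of these readings rests on a single pair, so it remains open whether the tert-butyl swap gives the same step with the other groups on the sulfonyl sulfur, as compound 1 and compound 2 have no partner here that differs from them at this position alone. Also open, going by these compounds, is whether a group of another kind at this position, such as an amine, a carboxylic acid or a longer chain, would give a step beyond the scatter.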